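Notes on ester-to-amide swap at the carbonyl carbon

The source may hold more compounds than are shown below. What is called first, only, known or untested is meant among the compounds shown, and "the series" means these compounds.

Measured compounds in an assay on membranes from CHO cells for displacement of a labelled ligand from adenosine receptor A1 (Homo sapiens), read by scintillation counting, with a stated time of 60 min, tested at 1 uM; a lower number here means less inhibition, a higher number more inhibition at the concentration tested (going by the name of the read-out):
compound 1 `CCCOC(=O)C1=C(C)NC(=O)NC1c1ccoc1`: 50%
compound 2 `CCCOC(=O)C1=C(C)NC(=O)NC1c1cccs1`: 43%
compound 3 `CCCOC(=O)C1=C(C)N(C)C(=O)NC1c1cccs1`: 9%

Compound 2 stands second highest of the three numbers in this assay; its nearest neighbour is compound 1, the gap being a number 7 percentage points lower from compound 1 to compound 2 (within the scatter), and its furthest is compound 3, reached by a number 34 percentage points lower from compound 2 to compound 3 (beyond the scatter).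

Compound 4 `CC1=C(C(=O)NC(C)C)C(c2cccs2)NC(=O)N1` is not yet measured. It differs from compound 2 in one place: isopropylamino in place of propoxy on a carbonyl carbon.

Neither measured step touches this carbonyl carbon. The step from compound 1 to compound 2 changes the aromatic ring on the saturated ring carbon and stays within the scatter; the step from compound 2 to compound 3 methylates an amide-type ring nitrogen and is large. Both nitrogens of the shared core are kept unchanged in compound 4, so the large drop does not transfer, and no shown step speaks for a change at the propoxycarbonyl position. The step from compound 2 to compound 4 in this assay is therefore expected to be a number 8 percentage points lower from compound 2 to compound 4 (within the scatter), not beyond the scatter, with wide uncertainty. For compound 4 the estimate in this assay is 35%, ranging from 10% to 65%.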

Compound 4, a percentage reported as inhibition, at one concentration (the size of the read-out at that concentration, not a potency): 2%
Compound 4: the middle estimate sits 33 percentage points above what was measured; the whole stated range lies above it.
By their numbers in this assay, from the lowest: compounds 4 and 3 (each within the scatter of the next); then compounds 2 and 1 (each within the scatter of the next).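

Among the compounds shown here, the carbonyl carbon proves to be a sensitive place in this assay: isopropylamino in place of propoxy gives a number 41 percentage points lower from compound 2 to compound 4 (beyond the scatter), a large step at a position that no earlier pair had probed. Compound 2 therefore has a second place where one change gives a large step, alongside the ring nitrogen methylation that gives a number 34 percentage points lower from compound 2 to compound 3 (beyond the scatter), even though the swap at the carbonyl carbon keeps the heavy-atom count and replaces an oxygen with a nitrogen that brings a hydrogen-bond donor. Nothing available accounts for the size of this step.

The compounds shown do not separate the effect of the amide nitrogen from that of the branched isopropyl chain, which an unbranched propylamino group on this carbonyl carbon would address. On these data alone, a carboxylic acid or a longer ester chain at this carbon, and the same swap with the furan-3-yl ring of compound 1, also remain open.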